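Expected Solubility of a 2-Hydroxyphenyl Isomer

The source may hold more compounds than are shown below. What is called first, only, known or untested is meant among the compounds shown, and "the series" means these compounds.

Of the compounds shown here, three with a shared core have been measured in a physicochemical assay for solubility, at pH 6.5; on this read-out lower numbers stand for lower solubility and higher numbers for higher solubility. There, compound 1 `O=C(Nc1ccc(Cl)cc1O)c1cc2cc(Cl)cc(Br)c2oc1=O` gives 0.11 ug/mL, compound 2 `O=C(Nc1ccc(O)cc1)c1cc2cc(Cl)cc(Br)c2oc1=O` gives 1.5 ug/mL, and compound 3 `O=C(Nc1cccc(O)c1)c1cc2cc(Cl)cc(Br)c2oc1=O` gives 1.4 ug/mL. Compound 3 thus stands level with compound 2, with a 1.1-fold lower number from compound 2 to compound 3 (0.03 log units; within the scatter), and far from compound 1, with a 13-fold higher number from compound 1 to compound 3 (1.10 log units; beyond the scatter).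

The next structure, compound 4 `O=C(Nc1ccccc1O)c1cc2cc(Cl)cc(Br)c2oc1=O`, has 2-hydroxyphenyl in place of 3-hydroxyphenyl on an amide-type nitrogen. Two kinds of measured step bear on this change. Exchanging one hydroxyphenyl group for another made no difference beyond the scatter in the one measured case, a 1.1-fold lower number from compound 2 to compound 3 (0.03 log units; within the scatter). Only compound 1 has a group of the 2-hydroxyphenyl kind, with a chloro substituent added. The large steps away from it, a 14-fold higher number from compound 1 to compound 2 (1.13 log units; beyond the scatter) and a 13-fold higher number from compound 1 to compound 3 (1.10 log units; beyond the scatter), each combine the loss of that chloro substituent with the change in hydroxyl placement, and the data cannot separate the two. A fall in this assay is therefore expected, though a smaller one than those large steps. The estimated step is a 3.5-fold lower number from compound 3 to compound 4 (0.54 log units; beyond the scatter). For compound 4 the estimated value is 0.4 ug/mL, with an expected range of 0.12 ug/mL to 1.3 ug/mL.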

Compound 4, solubility: 0.71 ug/mL
For compound 4 the middle estimate is 1.8-fold (0.25 log units) below the measured one; the measured number falls inside the stated range.
By their numbers in this assay, from the lowest: compound 1; then compounds 4, 3 and 2 (each within the scatter of the next, the first and the last beyond it).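

In this assay, the exchange of 3-hydroxyphenyl for 2-hydroxyphenyl on the amide-type nitrogen comes with a 2.0-fold lower number from compound 3 to compound 4 (0.29 log units; within the scatter), and the exchange of 4-hydroxyphenyl for 2-hydroxyphenyl comes with a 2.1-fold lower number from compound 2 to compound 4 (0.32 log units; beyond the scatter), so moving the hydroxyl among these three isomers separates only the last pair, and only modestly. Among these compounds, compound 4 also gives the first reading of the chloro substituent on its own: with the 2-hydroxyphenyl arrangement kept, hydrogen in place of chloro on an aromatic carbon comes with a 6.5-fold higher number from compound 1 to compound 4 (0.81 log units; beyond the scatter). The large steps away from compound 1, which earlier mixed two changes, can now be set against a single-change step for the chloro substituent and single-change steps for hydroxyl placement.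

No measurement among these compounds gives a reason for any of these steps. Going by these compounds, it remains open what a chloro substituent would do on the 3-hydroxyphenyl or 4-hydroxyphenyl groups, and whether a methoxy group, an amine or a carboxylic acid in place of the hydroxyl would stay close to these numbers in this assay.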